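Swapping a benzyl(methyl)amino arm for a pyridinylamino arm

The source may report more compounds than this note shows. Statements on the series, on what has been measured and on what is new or still open speak of the compounds shown alone.

Measured compounds:
Compound 1 `c1ccc(C2CCCCN2C2CCN(CCCc3c[nH]c4ccc(-n5cnnc5)cc34)CC2)cc1` gives 1.9 nM.
Compound 2 `CN(Cc1ccccc1)CC1CCN(CCCc2c[nH]c3ccc(-n4cnnc4)cc23)CC1` gives 0.9 nM.
Compound 3 `OC[C@H](NC1CCN(CCCc2c[nH]c3ccc(-n4ccnc4)cc23)CC1)c1ccccc1` gives 0.7 nM.

All three compounds share a common core and carry a side arm on a saturated ring; the read-out in each case comes from an assay on CHO cells for displacement of a labelled ligand from 5-hydroxytryptamine receptor 1D (Homo sapiens) (on this read-out lower numbers stand for stronger inhibition and higher numbers for weaker inhibition), so a low number is the welcome result. Compound 2 sits second highest among the three numbers. Its neighbour compound 3 lies within the usual scatter of repeated measurements, so the two cannot be told apart on these data. Compound 1, the furthest, lies beyond that scatter, and compound 2 therefore gives the lower number of the two.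

Compound 4 `c1ccc(NCC2CCN(CCCc3c[nH]c4ccc(-n5cnnc5)cc34)CC2)nc1` has not yet been measured in this assay. It differs from compound 2 in one place: (pyridin-2-yl)amino in place of benzyl(methyl)amino on a saturated chain carbon bound to a saturated ring carbon. Among the measured compounds shown here, no step between two measured compounds shows how this particular change plays out, so the expectation rests on the spread of the three measured values alone.

Compound 4 is expected to give a somewhat higher number, with a step from compound 2 of a 3.3-fold higher number from compound 2 to compound 4 (0.52 log units; beyond the scatter), a modest move, not certain to reach beyond the scatter. The estimate for compound 4 in this assay is 3 nM, with a range from 1 nM to 10 nM.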

Compound 4, half-maximal inhibitory concentration: 1.7 nM
Compound 4: middle estimate off by 1.8-fold (0.25 log units), on the high side; the range from low to high includes it.
By their numbers in this assay, from the lowest: compounds 3, 2, 4 and 1 (each within the scatter of the next, the first and the last beyond it).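

In this assay, replacing benzyl(methyl)amino with (pyridin-2-yl)amino on a saturated chain carbon bound to a saturated ring carbon gives a 1.9-fold higher number from compound 2 to compound 4 (0.28 log units; within the scatter) and so leaves compound 2 and compound 4 indistinguishable on this read-out. This is a sizeable exchange: the group that leaves has 9 heavy atoms, 0 hydrogen-bond donors and a ring of carbon only, while the group that enters has 7 heavy atoms, 1 hydrogen-bond donor and a ring with 1 hetero atom, so for this one pair the place accepts a clear change in the arm without a measurable shift in the number. Nothing available here explains why the two compounds read alike.

The swap alters the ring, the amine and the length of the arm together, so the compounds shown cannot separate these parts, and a phenylamino or a methyl(pyridin-2-yl)amino arm would help to pull them apart. Also open, from the compounds shown here alone, is how a carboxylic acid or a longer chain at this same place would read in this assay on the shared core.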